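Swapping a fluorophenyl for a pyridine, without a baseline

The source may hold more compounds than are shown below. What is called first, only, known or untested is meant among the compounds shown, and "the series" means these compounds.

Results so far in a functional assay on HeLa cells (Homo sapiens) for antiproliferative activity, read by CCK-8 assay, with a stated time of 72 h (on this read-out higher numbers stand for weaker inhibition and lower numbers for stronger inhibition), for three compounds:
Compound 1 `Nc1ccccc1NC(=O)c1ccc(CSC(=S)N2CCN(c3ccccc3)CC2)cc1` gives 840 nM
Compound 2 `Nc1ccccc1NC(=O)c1ccc(CSC(=S)N2CCN(c3ccc(F)cc3)CC2)cc1` gives "not determined" (no result reported)
Compound 3 `CC1CCCCN1C(=S)SCc1ccc(C(=O)Nc2ccccc2N)cc1` gives 2300 nM

Compound 2 has no place on this scale, since its entry reads "not determined" (no result reported) and no number exists to start from. The two numbers available come from its neighbours. Compound 1 stands at 840 nM and compound 3 stands at 2300 nM in this assay and a lower number here means stronger inhibition.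

The next compound to be tested is compound 4 `Nc1ccccc1NC(=O)c1ccc(CSC(=S)N2CCN(c3ccncc3)CC2)cc1` and it has no result yet. The structural change is pyridin-4-yl in place of 4-fluorophenyl on an amine nitrogen in a ring and it places pyridin-4-yl in place of 4-fluorophenyl on an amine nitrogen in a ring. The rest of the molecule stays the same.

Among the measured compounds shown here, no measured pair shows what such a swap does, so the size of this step cannot be read from the data. The expectation is therefore modest: no step beyond the usual scatter in this assay and no favoured direction, with compound 1 at 840 nM as the nearest guide. For compound 4 the expected value is 1000 nM with an estimated range from 350 nM to 3000 nM on this read-out.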

Compound 4, half-maximal inhibitory concentration: 790 nM
The estimate for compound 4 lay 1.3-fold (0.10 log units) above the measured number; low and high end bracket the measured number.
By their numbers in this assay, from the lowest: compounds 4 and 1 (each within the scatter of the next); then compound 3.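

In this assay, this place on the ring nitrogen now has its first readable step, a 1.1-fold lower number from compound 1 to compound 4 (0.03 log units; within the scatter), so a pyridin-4-yl ring, with one hetero atom and one hydrogen-bond acceptor, gives a number that cannot be told apart from that of a phenyl ring of carbon only. Among the compounds shown here, the swap actually posed, pyridin-4-yl in place of 4-fluorophenyl, cannot be read, since compound 2 has no number to start from, and the pair of compound 1 and compound 4 is the only guide to this position. No other measurement bears on this result, so the data offer no account of why these two compounds read alike.

This single pair leaves open whether the place of the nitrogen within the aromatic ring matters, which a pyridin-3-yl or pyridin-2-yl group on the same ring nitrogen would address. It also leaves open how far this position accepts groups of a different kind, such as a benzyl group, or a phenyl ring carrying a carboxylic acid or an amine.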